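This account rests on a few compounds, and the source may have more. Where it says the series, first, only, none or still open, it means among the compounds named here.

Measured in a functional assay (plasma) for inhibition, with Oryctolagus cuniculus as the target; on this read-out lower numbers stand for stronger inhibition and higher numbers for weaker inhibition:
- compound 1 `O=C(O)CCC/C=C\C[C@H]1[C@@H]2CCC(C2)[C@@H]1NS(=O)(=O)c1cccc2ccccc12`: 1100 nM
- compound 2 `CCCCCc1ccc(S(=O)(=O)N[C@H]2C3CC[C@H](C3)[C@@H]2C/C=C\CCCC(=O)O)cc1`: 800000 nM
- compound 3 `O=C(O)CCC/C=C\C[C@H]1[C@@H]2CCC(C2)[C@@H]1NS(=O)(=O)c1ccc([N+](=O)[O-])cc1`: 1400 nM

Compound 2 gives the highest of the three numbers in this assay; its nearest neighbour is compound 3, reached by a 570-fold lower number from compound 2 to compound 3 (2.76 log units; beyond the scatter), and the gap to compound 1 is wider still. Compound 1 and compound 3 sit close together, a 1.3-fold higher number from compound 1 to compound 3 (0.10 log units; within the scatter).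

The unmeasured compound 4 `CCc1ccc(S(=O)(=O)N[C@H]2C3CC[C@H](C3)[C@@H]2C/C=C\CCCC(=O)O)cc1` differs from compound 2 by hydrogen in place of propyl on a saturated chain carbon, two bonds along the chain from an aromatic carbon. The same difference, cut one bond further out, reads pentyl to ethyl. For the measured compounds named here, only one measured step touches this part of the structure, the step from compound 2 to compound 3, where nitro in place of pentyl on an aromatic carbon gave a large fall in the number. Going by the values given here, that step exchanges the pentyl for a different group altogether, so it does not say how a shortened chain alone behaves; it shows only that compound 2 is the outlier and that the aromatic substituent matters greatly. A step toward lower numbers is therefore expected, but of uncertain size and far from certain to reach the level of compound 3. Compound 4 is estimated at 100000 nM, with a range of 10000 nM to 800000 nM, corresponding to an expected step of an 8.0-fold lower number from compound 2 to compound 4 (0.90 log units; beyond the scatter).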

Compound 4, half-maximal inhibitory concentration: 4600 nM
For compound 4 the middle estimate is 22-fold (1.34 log units) above the measured one; measured number below the stated range.
By their numbers in this assay, from the lowest: compounds 1 and 3 (each within the scatter of the next); then compound 4; then compound 2.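

Shortening pentyl to ethyl, with nothing else changed in this assay, is enough on its own for a large fall (a 170-fold lower number from compound 2 to compound 4 (2.24 log units; beyond the scatter)), so the length of this chain matters without any exchange for a different kind of group. The ethyl group does not fully match the best of the series, as the modest steps to it show: ethyl in place of nitro (a 3.3-fold higher number from compound 3 to compound 4 (0.52 log units; beyond the scatter)) and 4-ethylphenyl in place of naphthalen-1-yl (a 4.2-fold higher number from compound 1 to compound 4 (0.62 log units; beyond the scatter)). No supporting data bear on why the chain length has so large an effect.

The compounds shown leave open whether the number climbs gradually or abruptly between ethyl and pentyl, which propyl and butyl would settle. Also open, as far as these compounds go, is how methyl, or an amine on the same aromatic carbon, compares with ethyl and nitro.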